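Cyclopropyl to Isopropyl on the Side Chain

A few compounds are considered here, and "the series" means these few. Any claim that something is new, unique, unknown or untested is made for them only; others in the source may bear on it.

Compound 2 `O=c1c(Cl)c(N2CCC(c3ccccc3)CC2)ccn1CC1CC1` is one of two measured compounds. In a functional assay on CHO cells for positive allosteric modulation of metabotropic glutamate receptor 2 (Homo sapiens), with a stated time of 30 min (on this read-out higher numbers stand for an effect only at larger amounts of compound and lower numbers for an effect already at smaller amounts), compound 2 gives 170 nM, and compound 1 `CC(C)Cn1ccc(N2CCC(c3ccccc3)CC2)c(C#N)c1=O` gives 282 nM; these two values lie within the scatter of each other, so compound 2 stands alongside compound 1 rather than apart from it. Compound 3 `CC(C)Cn1ccc(N2CCC(c3ccccc3)CC2)c(Cl)c1=O` has not been measured. It differs from compound 2 by isopropyl in place of cyclopropyl on a saturated chain carbon bound to an aromatic nitrogen, a swap of one small carbon group for another. Within the data shown here, no measured pair shows this change on its own, so the step is expected to be small, a 1.3-fold higher number from compound 2 to compound 3 (0.11 log units; within the scatter), with no clear direction beyond the scatter. Compound 3 is therefore expected to give 220 nM in this assay, within 90 nM to 550 nM.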

Compound 3, half-maximal effective concentration: 195 nM
Compound 3: middle estimate off by 1.1-fold (0.05 log units), on the high side; low and high end bracket the measured number.
By their numbers in this assay, from the lowest: compounds 2, 3 and 1 (each within the scatter of the next).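

In this assay, isopropyl in place of cyclopropyl on a saturated chain carbon bound to an aromatic nitrogen gives a 1.1-fold higher number from compound 2 to compound 3 (0.06 log units; within the scatter), so the ring in this side chain is not needed to keep the number in this range. Among these compounds, compound 3 also gives the first one-place comparison of chloro and cyano on an aromatic carbon: a 1.4-fold lower number from compound 1 to compound 3 (0.16 log units; within the scatter), so these two groups cannot be told apart here either. As far as these compounds go, whether a longer chain or an amine on the side chain would hold the number remains open, as does the effect of methoxy on that aromatic carbon. No supporting measurement bears on these results.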